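A few compounds are considered here, and "the series" means these few. Any claim that something is new, unique, unknown or untested is made for them only; others in the source may bear on it.

In an assay on isolated protein for inhibition of protein kinase C delta type (Homo sapiens), read by TR-FRET, with a stated time of 2 h (on this read-out lower numbers stand for stronger inhibition and higher numbers for weaker inhibition), compound 1 `N#Cc1cnc(NCc2cnccc2C(F)(F)F)cc1N[C@H]1CC[C@@H](O)CC1` gives 4500 nM. Compound 2 `CC1(C)C[C@@H](Nc2cc(NCc3cnccc3C(F)(F)F)ncc2C#N)CC[C@@H]1O` gives 2400 nM, the lower-reading of the two numbers, although a 1.9-fold lower number from compound 1 to compound 2 (0.27 log units; within the scatter) shows that the gap lies within the scatter. Compound 3 `CC1(C)[C@@H](C(N)=O)C[C@H]1Nc1cc(NCc2cnccc2C(F)(F)F)ncc1C#N` differs from compound 2 by 3-carbamoyl-2,2-dimethylcyclobutyl in place of 4-hydroxy-3,3-dimethylcyclohexyl on a nitrogen on an aromatic ring. For the measured compounds named here, no measured step bears directly on swapping a six-membered ring for a four-membered one; the only step known, a 1.9-fold lower number from compound 1 to compound 2 (0.27 log units; within the scatter), stayed within the scatter. The step is therefore expected to be small, a 1.3-fold higher number from compound 2 to compound 3 (0.10 log units; within the scatter), with no clear direction. Compound 3 is estimated at 3000 nM, within a range from 800 nM to 12000 nM.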

Compound 3, half-maximal inhibitory concentration: 160 nM
For compound 3 the middle estimate is 19-fold (1.27 log units) above the measured one, outside the stated range (below it).
By their numbers in this assay, from the lowest: compound 3; then compounds 2 and 1 (each within the scatter of the next).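

The group on this nitrogen can move the number far more than compounds 1 and 2 suggested: in this assay there is a 15-fold lower number from compound 2 to compound 3 (1.18 log units; beyond the scatter) and also a 28-fold lower number from compound 1 to compound 3 (1.45 log units; beyond the scatter). The leaving and entering groups have the same count of heavy atoms, hydrogen-bond donors and acceptors, so those counts do not track the change. Nothing measured here explains the gain.

Ring size and the carbamoyl group changed together, so their contributions cannot be separated. A carbamoyl on the six-membered ring would separate them, while a carboxylic acid or an amine on the cyclobutyl ring would test whether the carbamoyl itself is needed.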